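Amide Nitrogen Substituent Exchange in a TRPM8 Agonist Series

This account rests on a few compounds, and the source may have more. Where it says the series, first, only, none or still open, it means among the compounds named here.

Of the compounds shown here, three have been measured in an assay on HEK293 cells for agonist activity at transient receptor potential cation channel subfamily M member 8 (Homo sapiens), read by fluorescence and calcium flux, with a stated time of 15 min; on this read-out higher numbers stand for an effect only at larger amounts of compound and lower numbers for an effect already at smaller amounts. Compound 1 `Cc1ccc(OCC(=O)N(CCO)Cc2cccs2)cc1` gives 900 nM, the lowest number of the three. Among the compounds with values here, compound 2 `CCN(Cc1ccccc1)C(=O)COc1ccc(C)cc1` gives 1880 nM, and compound 3 `CCN(Cc1ccccn1)C(=O)COc1ccc(C)cc1` gives 16000 nM; the only single-site step among them, an 8.5-fold higher number from compound 2 to compound 3 (0.93 log units; beyond the scatter), concerns the group on the chain carbon and not the amide nitrogen. Compound 4 `CON(Cc1cccs1)C(=O)COc1ccc(C)cc1` differs from compound 1 at that nitrogen: methoxy in place of 2-hydroxyethyl on an amide-type nitrogen. Within the data shown here, no measured step bears on this position, so the expectation rests on compound 1 alone; a step of a 1.8-fold higher number from compound 1 to compound 4 (0.25 log units; within the scatter) is estimated in this assay, leaning toward a higher number. Compound 4 is therefore expected to give about 1600 nM, within 500 nM to 5000 nM.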

Compound 4, half-maximal effective concentration: 10 nM
Compound 4: middle estimate off by 160-fold (2.20 log units), on the high side; measured number below the stated range.
By their numbers in this assay, from the lowest: compound 4; then compound 1; then compound 2; then compound 3.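

Within the data shown here, the amide nitrogen proves to be a highly sensitive position in this assay, which the earlier compounds could not show, as their only single-site step lay on the chain carbon. Methoxy in place of 2-hydroxyethyl gives a 90-fold lower number from compound 1 to compound 4 (1.95 log units; beyond the scatter), a change that also goes from 1 hydrogen-bond donor to 0 donors. Nothing available explains this step. The compounds shown leave open whether the gain follows the oxygen bound directly to the nitrogen or the loss of the hydroxyl. Ethoxy or 2-methoxyethyl at this nitrogen would separate these readings.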